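Phenylsulfonyl in place of 4-methoxyphenyl on the shared core

This account rests on a few compounds, and the source may have more. Where it says the series, first, only, none or still open, it means among the compounds named here.

Compound 1 `CCOC(=O)c1cnc(-c2ccc(OC)cc2)nc1NN1C(=O)C=C(C)C1=O` carries a 4-methoxyphenyl group on the shared core. In a functional assay on Jurkat cells for inhibition of nuclear factor NF-kappa-B complex (Homo sapiens) (on this read-out lower numbers stand for stronger inhibition and higher numbers for weaker inhibition), compound 1 gives 900 nM, the highest of the three measured numbers. Compound 2 `CCOC(=O)c1cnc(-c2ccc(Cl)s2)nc1NN1C(=O)C=C(C)C1=O` gives 300 nM in this assay, and compound 3 `CCOC(=O)c1cnc(C(=O)c2ccco2)nc1NN1C(=O)C=C(C)C1=O` gives 700 nM. Of the steps from compound 1, only a 3.0-fold lower number from compound 1 to compound 2 (0.48 log units; beyond the scatter) lies beyond the scatter, while a 1.3-fold lower number from compound 1 to compound 3 (0.11 log units; within the scatter) stays within it; the two replacements themselves differ by a 2.3-fold higher number from compound 2 to compound 3 (0.37 log units; beyond the scatter).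

Compound 4 `CCOC(=O)c1cnc(S(=O)(=O)c2ccccc2)nc1NN1C(=O)C=C(C)C1=O` differs from compound 1 by phenylsulfonyl in place of 4-methoxyphenyl on an aromatic carbon. The closest guide is compound 3, where the aryl ring is likewise held off the core through a linking group, a carbonyl there, and that step, a 1.3-fold lower number from compound 1 to compound 3 (0.11 log units; within the scatter), stayed within the scatter. The step of a 3.0-fold lower number from compound 1 to compound 2 (0.48 log units; beyond the scatter) placed a different ring directly on the core and bears less on a sulfonyl-linked phenyl. For compound 4 no change beyond the scatter is therefore expected; the expected step is a 1.1-fold higher number from compound 1 to compound 4 (0.05 log units; within the scatter). Compound 4 is estimated at 1000 nM in this assay, within a range from 400 nM to 2500 nM.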

Compound 4, half-maximal inhibitory concentration: 10000 nM
The estimate for compound 4 lay 10-fold (1.00 log units) below the measured number; measured number above the stated range.
By their numbers in this assay, from the lowest: compound 2; then compounds 3 and 1 (each within the scatter of the next); then compound 4.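

In this assay, among the compounds shown here, the ring carbon between two ring nitrogen atoms turns out not to accept every ring-bearing group alike: phenylsulfonyl gives an 11-fold higher number from compound 1 to compound 4 (1.05 log units; beyond the scatter), the first large step. The loss is not shared by every linked ring, as the carbonyl-linked furan-2-yl group gives way to phenylsulfonyl with a 14-fold higher number from compound 3 to compound 4 (1.15 log units; beyond the scatter), and the directly attached 5-chlorothiophen-2-yl group with a 33-fold higher number from compound 2 to compound 4 (1.52 log units; beyond the scatter). No data at hand bear on the reason for this drop.

Still open, as far as these compounds go, is whether the loss follows the sulfonyl link or the unsubstituted phenyl ring, since compound 3 differs from compound 4 in both the link and the ring. A benzoyl group, a phenylthio group or a 4-methoxyphenylsulfonyl group at this position would separate the two.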